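Bromothiophene for Furan on the Enone Carbonyl

This account rests on a few compounds, and the source may have more. Where it says the series, first, only, none or still open, it means among the compounds named here.

Among the compounds with values here, compound 2 `COc1ccc(-c2cc3ccccc3nc2/C=C/C(=O)c2ccco2)cc1` gives 6240 nM in a functional assay on H184B5F5/M10 cells (Homo sapiens) for antiproliferative activity, read by XTT assay, with a stated time of 72 h (on this read-out higher numbers stand for weaker inhibition and lower numbers for stronger inhibition), the higher of the two numbers so far, though the gap to its only neighbour is within the scatter: compound 1 `COc1ccc(-c2cc3ccccc3nc2/C=C/C(=O)c2ccc(OC)cc2OC)cc1` gives 6110 nM in this assay. Compound 3 `COc1ccc(-c2cc3ccccc3nc2/C=C/C(=O)c2ccc(Br)s2)cc1` differs from compound 2 by 5-bromothiophen-2-yl in place of furan-2-yl on a carbonyl carbon. Within the data shown here, the one step that bears on it, a 1.0-fold higher number from compound 1 to compound 2 (0.01 log units; within the scatter), also exchanged the group on that carbonyl carbon and left the number essentially unchanged, so no step beyond the scatter is expected here. Compound 3 is therefore estimated at 6000 nM, with a range of 2500 nM to 14000 nM, an expected 1.0-fold lower number from compound 2 to compound 3 (0.02 log units; within the scatter).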

Compound 3, half-maximal inhibitory concentration: 9380 nM
Estimate against measurement, compound 3: 1.6-fold (0.19 log units) below; measured number inside the range.
By their numbers in this assay, from the lowest: compounds 1, 2 and 3 (each within the scatter of the next).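

In this assay the carbonyl carbon has now carried three different groups, and neither new step leaves the scatter: a 1.5-fold higher number from compound 2 to compound 3 (0.18 log units; within the scatter) and a 1.5-fold higher number from compound 1 to compound 3 (0.19 log units; within the scatter). At this position, then, 5-bromothiophen-2-yl sits level with both furan-2-yl and 2,4-dimethoxyphenyl, so even a group containing sulfur and bromine has not produced a clear change. Nothing measured here accounts for these numbers. Still open, from the compounds shown here alone, is whether a group such as an amine or a carboxylic acid on this carbonyl carbon would move the number beyond the scatter.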